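Chloro for Methyl on Two Related Cores

A few compounds are considered here, and "the series" means these few. Any claim that something is new, unique, unknown or untested is made for them only; others in the source may bear on it.

Compound 1, `COc1cc2c(cc1OC)C(=O)/C(=C/c1cccc(Cl)c1)CC2`, in a functional assay on Jurkat cells (Homo sapiens) for antiproliferative activity, read by MTT assay (on this read-out higher numbers stand for weaker inhibition and lower numbers for stronger inhibition), gives 9000 nM.
Compound 2, `COc1cc2c(cc1OC)C(=O)/C(=C/c1cccc(C)c1)CC2`, in this assay gives 17000 nM.
Compound 3, `COc1cc2c(cc1OC)C(=O)/C(=C/c1cccc(C)c1)C2`, in this assay gives 1800 nM.

Compounds 1 and 2 share one core and differ only in the substituent on the pendant aromatic ring. The change from compound 2 to compound 1 is chloro in place of methyl on an aromatic carbon and it made a 1.9-fold lower number from compound 2 to compound 1 (0.28 log units; within the scatter), so these two compounds are not separated in this assay.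

Compound 3 stands on a different core; how that core differs from the core of compound 2 is not broken down here. Compound 3 has the lowest number of the three, and its distances to compound 1 and to compound 2 both lie beyond the scatter, so on the present data it is the most potent of the measured compounds.

Compound 4, `COc1cc2c(cc1OC)C(=O)/C(=C/c1cccc(Cl)c1)C2`, has not yet been measured. It differs from compound 3 by chloro in place of methyl on an aromatic carbon, and since the surroundings of the changed carbon are described in the same words for both pairs, this is the same change that was made from compound 2 to compound 1. Because that earlier step was a 1.9-fold lower number from compound 2 to compound 1 (0.28 log units; within the scatter), compound 4 is expected to make a step of similar size, a 1.8-fold lower number from compound 3 to compound 4 (0.26 log units; within the scatter), from compound 3. Compound 4 is therefore estimated at 1000 nM in this assay, with a plausible range from 400 nM to 2500 nM.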

Compound 4, half-maximal inhibitory concentration: 8000 nM
The estimate for compound 4 lay 8.0-fold (0.90 log units) below the measured number; the measured number lies above the stated range.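

On the core of compound 3, the change from 3-methylphenyl to 3-chlorophenyl did not repeat what it had done on the other core, giving in this assay a 4.4-fold higher number from compound 3 to compound 4 (0.65 log units; beyond the scatter). The earlier step did not separate its two compounds while this one does, so the result of the change on one core could not be taken over to the other, and the two steps differ by more than their combined scatter: the same change on two cores in this assay, a 1.9-fold lower number (0.28 log units; within the scatter) from compound 2 to compound 1 and a 4.4-fold higher number (0.65 log units; beyond the scatter) from compound 3 to compound 4, 8.4-fold (0.92 log units) apart, beyond the scatter of two such steps. This shows that, for these two cores in this one assay, the outcome of this single change depends on the core it is made on, but it does not show what in the cores is responsible, nor whether another substituent on the pendant aromatic ring would behave in the same way.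

The compounds shown carry only methyl or chloro at one place on the pendant ring, so it remains open how a fluoro, a methoxy or an amine there would fare on either core. Also open, as far as these compounds go, is whether the two methoxy groups could give way to a hydroxyl or a longer chain without altering this dependence, and whether a third core would side with either of the two steps.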